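Replacing the azido group on the sulfonyl sulfur

The compounds below may be only part of what the source reports. "The series", "measured", "known", "first", "only" and "open" are said of these compounds alone.

Within the data shown here, compound 1 `CC1(C)C=C(n2ccccc2=O)c2cc(S(=O)(=O)N=[N+]=[N-])ccc2O1` gives 88.3% in a functional assay on the whole organism (aorta) with Rattus norvegicus as the target (a higher number here means a larger maximal response, a lower number a smaller maximal response), the highest of the three numbers measured so far. Compound 3 `CC1(C)C=C(n2ccccc2=O)c2cc(S(=O)(=O)N3CCOCC3)ccc2O1` gives 75.5% and compound 2 `CC1(C)C=C(n2ccccc2=O)c2cc(S(=O)(=O)NCc3ccccc3)ccc2O1` gives 71.1%; both lie below compound 1 beyond the usual scatter, compound 3 nearer and compound 2 further. Compound 4 `CC1(C)C=C(n2ccccc2=O)c2cc(S(=O)(=O)NC(=O)Nc3ccccc3)ccc2O1` carries the change ((phenylcarbamoyl)amino in place of azido on a sulfonyl sulfur). Among the measured compounds shown here, two measured steps bear on it, both replacing azido on the sulfonyl sulfur: a number 17.2 percentage points lower from compound 1 to compound 2 (beyond the scatter) and a number 12.8 percentage points lower from compound 1 to compound 3 (beyond the scatter). Between the two replacements themselves the numbers lie within the scatter of each other: a number 4.4 percentage points higher from compound 2 to compound 3 (within the scatter). A modest fall below compound 1 is therefore expected once more, of a size close to these two steps, not a rise; compound 2 and compound 3 give no ground for expecting a loss larger than theirs. Compound 4 is expected to reach 72%, in the range 60% to 85%, which means a step of a number 16.3 percentage points lower from compound 1 to compound 4 (beyond the scatter).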

Compound 4, largest response reached (Emax), in percent of the reference or control that the assay uses: 90.8%
Compound 4: the middle estimate sits 18.8 percentage points below what was measured, and the stated range ends below it.
By their numbers in this assay, from the lowest: compounds 2 and 3 (each within the scatter of the next); then compounds 1 and 4 (each within the scatter of the next).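

In this assay replacing azido on the sulfonyl sulfur need not lower the number: with (phenylcarbamoyl)amino the step is a number 2.5 percentage points higher from compound 1 to compound 4 (within the scatter) and the two groups stand level, unlike benzylamino and morpholin-4-yl. The group on the sulfonamide nitrogen also counts, although benzyl and phenylcarbamoyl each bring an aromatic ring: phenylcarbamoyl in place of benzyl gives a number 19.7 percentage points higher from compound 2 to compound 4 (beyond the scatter) and (phenylcarbamoyl)amino in place of morpholin-4-yl gives a number 15.3 percentage points higher from compound 3 to compound 4 (beyond the scatter) in the same direction. Nothing measured here accounts for these steps.

Which part of the phenylcarbamoyl group carries the difference from benzyl stays open, since an acetyl or plain carbamoyl group on the sulfonamide nitrogen would separate the carbonyl from the phenyl ring. Also open, as far as these compounds go, is whether a free amino group on the sulfonyl sulfur would stand with azido and (phenylcarbamoyl)amino or with benzylamino and morpholin-4-yl.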